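The Step from Compound 3 to Compound 4

The source may hold more compounds than are shown below. What is called first, only, known or untested is meant among the compounds shown, and "the series" means these compounds.

Among the compounds with values here, in an ADME assay on microsomes from liver (Homo sapiens) for metabolic stability, read by LC-MS, tested at 1 uM (a higher number here means faster removal of the compound, a lower number slower removal), compound 3 (`NCCS(=O)(=O)CCOc1ccc([C@H]2CC[C@]3(CC2)OOC2(O3)C3CC4CC(C3)CC2C4)cc1`) gives 9 mL.min-1.g-1 as the only actual number in the set. Compound 1 (`NCCOc1ccc([C@H]2CC[C@]3(CC2)OOC2(O3)C3CC4CC(C3)CC2C4)cc1`) stands at < 7 mL.min-1.g-1 as a limit of the assay. Compound 2 (`CC(C)(N)CCOc1ccc([C@H]2CC[C@]3(CC2)OOC2(O3)C3CC4CC(C3)CC2C4)cc1`) stands at < 7 mL.min-1.g-1 as a limit too. In compound 4 (`CC(C)(CN)Oc1ccc([C@H]2CC[C@]3(CC2)OOC2(O3)C3CC4CC(C3)CC2C4)cc1`), 1-(aminomethyl)-1-methylethyl takes the place of 2-((2-aminoethyl)sulfonyl)ethyl on an oxygen on an aromatic ring, a change counted as 1-(aminomethyl)-1-methylethyl in place of 2-((2-aminoethyl)sulfonyl)ethyl on an oxygen on an aromatic ring and leaving no sulfonyl in the chain.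

Within the data shown here, two measured steps bear on this change: an at least 1.2-fold higher number from compound 1 to compound 3 (0.10 log units; that floor lies within the scatter), and an at least 1.2-fold higher number from compound 2 to compound 3 (0.10 log units; that floor lies within the scatter), each only a floor within the scatter. The third, a step that the two limits leave unreadable from compound 1 to compound 2, gives no size. Compound 4 resembles compound 1 and compound 2 in lacking the sulfonyl, so reading an at least 1.2-fold higher number from compound 2 to compound 3 (0.10 log units; that floor lies within the scatter) backwards, a slight fall but nothing beyond the scatter is expected. The expected change is a 1.5-fold lower number from compound 3 to compound 4 (0.18 log units; within the scatter) in this assay, and the reading may well be only a limit. Compound 4 is estimated at 6 mL.min-1.g-1, within an expected range of 3 mL.min-1.g-1 to 11 mL.min-1.g-1 overall.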

Compound 4, intrinsic clearance in microsomes: < 7 mL.min-1.g-1
Compound 4 ended at the assay's limit; the forecaster's own chance of this, stated with the estimate: 60%; the middle value lies beyond the limit too.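

In this assay compound 4 gives < 7 mL.min-1.g-1, which is a limit of the assay and not a number. Going by these compounds, replacing 2-((2-aminoethyl)sulfonyl)ethyl with the shorter, branched 1-(aminomethyl)-1-methylethyl gives an at least 1.2-fold lower number from compound 3 to compound 4 (0.10 log units; that floor lies within the scatter), so the size of this change remains unknown. A third chain without the sulfonyl now sits at the limit alongside compound 1 and compound 2, while compound 3, the only one of these four that carries a sulfonyl, goes against that pattern with a measured number.

On these data alone, the steps joining compound 4 to compound 1 and compound 2 cannot be read, because all three compounds stand at a limit: the limit of < 7 mL.min-1.g-1 in this assay, at which 3 of the 4 values shown sit. It remains open whether a carboxylic acid in place of the amine, or a longer chain without the sulfonyl, on this oxygen would give a reading clear of the limit.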